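Propyl for cyclopropyl in a series at the limit

This account rests on a few compounds, and the source may have more. Where it says the series, first, only, none or still open, it means among the compounds named here.

- compound 1 `CCCN1C(=O)[C@@H](NC(=O)c2cccc(C)c2)[C@@H](c2ccc(F)cc2)c2c1nn(CCC)c2C`: > 25000 nM (a limit)
- compound 2 `CCOC1=Nc2c(c(C)nn2-c2ccccc2)[C@H](c2ccc(F)cc2)[C@@H]1NC(=O)c1cccc(C)c1`: > 25000 nM (a limit)
- compound 3 `CCN1C(=O)[C@@H](NC(=O)c2cccc(C)c2)[C@@H](c2ccc(F)cc2)c2c(C)nn(C3CC3)c21`: > 25000 nM (a limit)

In an ADME assay on BJ cells (Homo sapiens) for inhibition, read by CellTiter-Glo, with a stated time of 72 h (on this read-out higher numbers stand for an effect only at larger amounts of compound and lower numbers for an effect already at smaller amounts), compound 3 gives > 25000 nM as a limit and not a number. All three measured compounds stand at the limit of > 25000 nM in this assay, at which 3 of the 3 values shown sit, so no graded value is available. Compound 4 `CCCn1nc(C)c2c1N(CC)C(=O)[C@@H](NC(=O)c1cccc(C)c1)[C@H]2c1ccc(F)cc1` differs from compound 3 by propyl in place of cyclopropyl on an aromatic nitrogen. Compound 1 also carries propyl on an aromatic nitrogen, and its > 25000 nM is a limit. In this assay the expected step, a number no higher from compound 3 to compound 4 (the limit leaves the size open), is none beyond the scatter. For compound 4 the estimated value is 25000 nM, with an expected range from 12000 nM to 50000 nM, and a further limit is the likeliest report.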

Compound 4, half-maximal effective concentration in the BJ assay: > 25000 nM
Compound 4 gave a limit, no number (the forecaster's own chance of this, stated with the estimate: 85%); the middle value sits exactly at the limit.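

In the BJ assay compound 3 gives > 25000 nM, a limit and not a number. In the BJ assay compound 4 gives > 25000 nM, also a limit and not a number. Compound 3 and compound 4 both give a limit in the BJ assay, so no step between them can be read: the limit of > 25000 nM in the BJ assay, at which 4 of the 4 values shown sit.

The compounds shown leave open whether propyl in place of cyclopropyl on an aromatic nitrogen changes the BJ assay at all. In a physicochemical assay for solubility, measured as kinetic solubility, at pH 7.4 (on this read-out lower numbers stand for lower solubility and higher numbers for higher solubility), compound 3 gives 46100 nM and compound 4, with propyl in place of cyclopropyl on an aromatic nitrogen, gives 10900 nM: the measured solubility of compound 3, 46100 nM, and of compound 4, 10900 nM, a 4.2-fold lower number (0.63 log units; beyond the scatter)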